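The source may report more compounds than this note shows. Statements on the series, on what has been measured and on what is new or still open speak of the compounds shown alone.

Measured in a functional assay on SMMC-7721 cells (Homo sapiens) for antiproliferative activity, read by CCK-8 assay, with a stated time of 72 h; on this read-out higher numbers stand for weaker inhibition and lower numbers for stronger inhibition:
compound 1 `CCc1ccc(SCc2ccc(C(=O)Nc3ccccc3N)cc2)cc1`: 1750 nM
compound 2 `Nc1ccccc1NC(=O)/C=C/c1ccc(CSc2ccc(F)cc2)cc1`: "not determined" (no result reported)
compound 3 `Nc1ccccc1NC(=O)c1ccc(CSc2nccc(C(F)(F)F)n2)cc1`: 1890 nM

Compound 1 and compound 3 lie within the usual scatter of each other, and compound 2 supplies no number, so compound 1 stands level with the only other figure available. The next compound to be tested is compound 4 `Nc1ccccc1NC(=O)c1ccc(CSCCc2ccccc2)cc1`, which has the same atoms as compound 1, joined differently: phenethyl in place of 4-ethylphenyl on a sulfur. In words, phenethyl comes in place of 4-ethylphenyl on a sulfur. For the measured compounds named here, no two measured compounds differ in one place only, so the data offer no direct guide to this change. With compound 1 at 1750 nM as the anchor, no step beyond the scatter is expected in this assay. The estimated step, a slight one toward weaker inhibition, is a 1.3-fold higher number from compound 1 to compound 4 (0.10 log units; within the scatter). For compound 4 the expected value is 2200 nM, with an estimated range from 750 nM to 6500 nM.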

Compound 4, half-maximal inhibitory concentration: 4880 nM
For compound 4 the middle estimate is 2.2-fold (0.35 log units) below the measured one; measured number inside the range.
By their numbers in this assay, from the lowest: compounds 1 and 3 (each within the scatter of the next); then compound 4.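

In this assay, for the compounds shown here, the step on this sulfur is a 2.8-fold higher number from compound 1 to compound 4 (0.45 log units; beyond the scatter), a modest change and the first one in these compounds that can be read at a single place. Phenethyl and 4-ethylphenyl match in heavy atoms, aromatic ring and hydrogen-bond counts, so at this position the way the same atoms are joined is enough to weaken inhibition, even though the overall composition stays the same. No measurement available here accounts for this difference.

The compounds shown leave open whether benzyl or a longer chain ending in a phenyl ring on the sulfur would fall nearer to compound 1 or to compound 4. They also leave open whether an amine or a carboxylic acid on the phenethyl ring would alter the step.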